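Methylphenyl to methylbenzyl on the central chain carbon

The source may report more compounds than this note shows. Statements on the series, on what has been measured and on what is new or still open speak of the compounds shown alone.

Measured so far in an assay on CHO cells for antagonist activity at transient receptor potential cation channel subfamily V member 1 (Homo sapiens), read by FLIPR; on this read-out lower numbers stand for stronger inhibition and higher numbers for weaker inhibition:
compound 1 `Cc1ccccc1C(C(=O)NCc1ccc(C(F)(F)F)nc1N1CCC(C)CC1)c1ccc(NS(C)(=O)=O)c(F)c1`: 42.9 nM
compound 2 `Cc1cccc(C(C(=O)NCc2ccc(C(F)(F)F)nc2N2CCC(C)CC2)c2ccc(NS(C)(=O)=O)c(F)c2)c1`: 0.1 nM
compound 3 `Cc1ccc(C(C(=O)NCc2ccc(C(F)(F)F)nc2N2CCC(C)CC2)c2ccc(NS(C)(=O)=O)c(F)c2)cc1`: 1.1 nM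

Compound 3 holds the second highest of the three numbers. Its nearest neighbour is compound 2, as an 11-fold higher number from compound 2 to compound 3 (1.04 log units; beyond the scatter) shows; its furthest is compound 1, as a 39-fold lower number from compound 1 to compound 3 (1.59 log units; beyond the scatter) shows. The third measured step, a 430-fold lower number from compound 1 to compound 2 (2.63 log units; beyond the scatter), likewise concerns only the position of the methyl on the aryl group at the chain carbon.

Compound 4 `Cc1ccc(CC(C(=O)NCc2ccc(C(F)(F)F)nc2N2CCC(C)CC2)c2ccc(NS(C)(=O)=O)c(F)c2)cc1` is not yet measured. It differs from compound 3 by 4-methylbenzyl in place of 4-methylphenyl on a saturated chain carbon bound to an aromatic carbon and a carbonyl carbon. For the measured compounds named here, no measured step touches this kind of change: all three measured steps move a methyl around the same ring, none inserts the extra chain member that turns the aryl into a benzyl. The step of a 3.6-fold higher number from compound 3 to compound 4 (0.56 log units; beyond the scatter) is therefore an estimate only, resting on compound 3 alone with a wide range. Compound 4 is expected to give about 4 nM, between 0.5 nM and 40 nM in this assay.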

Compound 4, inhibition constant: "active" (no number reported)
Compound 4: no number reported, so the estimate cannot be set against anything.
By their numbers in this assay, from the lowest: compound 2; then compound 3; then compound 1.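

In this assay, for the compounds shown here, compound 4 is reported only as active, without a number, so no step from compound 3 to compound 4 can be read. On these data alone, how far 4-methylbenzyl in place of 4-methylphenyl moves the number stays open. No evidence on this change is available.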